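The source may hold more compounds than are shown below. What is called first, only, known or untested is meant among the compounds shown, and "the series" means these compounds.

Among the compounds with values here, in a functional assay on KB-VIN10 cells (Homo sapiens) for inhibition, with a stated time of 72 h (on this read-out lower numbers stand for stronger inhibition and higher numbers for weaker inhibition), two compounds with a shared core have numbers so far. Compound 1 (`COc1ccc(S(=O)(=O)N2CCc3cccc(-c4ccc(N)cc4)c32)cc1`) gives 262 nM there. Compound 2 (`COc1ccc(S(=O)(=O)N2CCc3cccc(-c4ccco4)c32)cc1`) gives 79.2 nM there, the lower of the two numbers and so the stronger inhibition of the pair. Compound 3 (`COc1ccc(S(=O)(=O)N2CCc3cccc(-c4ccc(F)c(F)c4)c32)cc1`) keeps the same core and changes one group, with 3,4-difluorophenyl in place of furan-2-yl on an aromatic carbon. Within the data shown here, only one measured step bears on this place: swapping 4-aminophenyl for furan-2-yl gave a 3.3-fold lower number from compound 1 to compound 2 (0.52 log units; beyond the scatter) and counts as modest. Compound 1, at 262 nM in this pair, carries a six-membered aromatic ring of carbon only at this place, and compound 3 does too. In this assay a step toward a higher number is therefore expected, smaller than that measured one and near the edge of the scatter. The expected step is a 2.1-fold higher number from compound 2 to compound 3 (0.33 log units; beyond the scatter) in size, and it rests on a single comparison, so the uncertainty is wide. For compound 3 the estimated value is 170 nM with 50 nM to 550 nM as the expected range.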

Compound 3, half-maximal inhibitory concentration: 46 nM
The estimate for compound 3 lay 3.7-fold (0.57 log units) above the measured number; the measured number lies below the stated range.
By their numbers in this assay, from the lowest: compounds 3 and 2 (each within the scatter of the next); then compound 1.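

In this assay, putting 3,4-difluorophenyl in place of furan-2-yl gives a 1.7-fold lower number from compound 2 to compound 3 (0.24 log units; within the scatter) and so does not separate a five-membered aromatic ring with a hetero atom from a six-membered aromatic ring of carbon only at this place on the shared core. Compounds 1 and 3 both carry a six-membered aromatic ring of carbon only, yet 3,4-difluorophenyl in place of 4-aminophenyl gives a 5.7-fold lower number from compound 1 to compound 3 (0.76 log units; beyond the scatter) and shows that this kind of ring does not by itself bring the higher number of compound 1: at this place, what the ring carries also matters. Nothing measured here explains why either step has the size it has.

The compounds shown do not tell whether the gap between compound 1 and compound 3 comes from the amine, from the fluorines or from both, and a plain phenyl ring with only hydrogens on it would be the direct comparison for that. They also leave open how other five-membered aromatic rings, such as thiophene, would compare with furan-2-yl at this place.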